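Adding an acetyl group to compound 1

The source may hold more compounds than are shown below. What is called first, only, known or untested is meant among the compounds shown, and "the series" means these compounds.

In a functional assay on U-251 cells (Homo sapiens) for cytotoxicity, read by sulforhodamine B assay, with a stated time of 72 h (a higher number here means that more compound is needed for the effect, a lower number that less compound is needed), compound 1 `OCc1c(-c2ccccc2)[nH]c2ccccc12` gives 130000 nM. Within the data shown here, its only measured neighbour, compound 2 `OCCc1c(-c2ccccc2)[nH]c2ccccc12`, gives 250000 nM, so the two stand level within the scatter. Compound 3 `CC(=O)n1c(-c2ccccc2)c(CO)c2ccccc21` keeps the hydroxymethyl group of compound 1 and differs elsewhere: acetyl in place of hydrogen on an aromatic nitrogen. Put simply, acetyl takes the place of hydrogen on an aromatic nitrogen. Among the measured compounds shown here, the one measured step, a 1.9-fold higher number from compound 1 to compound 2 (0.28 log units; within the scatter), is small, but it concerns the chain carrying the hydroxy group, not this nitrogen, so it bears on the change only loosely. For the measured compounds named here, no measured compound carries a group on that nitrogen, and the data show neither the size nor the direction of such a change. The expected result in this assay is therefore no shift beyond the scatter, namely an estimated 1.3-fold lower number from compound 1 to compound 3 (0.11 log units; within the scatter). Compound 3 is estimated at 100000 nM, with an expected range from 30000 nM to 300000 nM.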

Compound 3, half-maximal effective concentration: 600000 nM
Beside the measured number, compound 3's estimate is 6.0-fold (0.78 log units) below it; the whole stated range lies below it.
By their numbers in this assay, from the lowest: compounds 1 and 2 (each within the scatter of the next); then compound 3.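

Acetyl in place of hydrogen on the aromatic nitrogen of compound 1 gives, in this assay, a 4.6-fold higher number from compound 1 to compound 3 (0.66 log units; beyond the scatter) and is the first step shown here to lie beyond the scatter. This nitrogen is therefore a position where a change can register in the read-out, whereas the earlier step on the chain carrying the hydroxy group stayed within the scatter. With acetyl on this nitrogen, more compound is needed for the effect, but no supporting measurement accounts for the shift, so it stands as an observation only.

The compounds shown leave open whether a methyl or a benzoyl group on the same nitrogen would move the number in the same direction. They also leave open whether acetyl would have a similar effect on compound 2.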